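Aryl swap on the amine nitrogen: compound 3 to compound 4

This account rests on a few compounds, and the source may have more. Where it says the series, first, only, none or still open, it means among the compounds named here.

Compound 3 `COc1ccc(N/C(CCNC2=CC(=O)c3ccccc3C2=O)=N\S(=O)(=O)c2ccc(C)cc2)c(OC)c1` carries a 2,4-dimethoxyphenyl on the amine nitrogen. In a functional assay on A549 cells (Homo sapiens) for cytotoxicity, read by MTT assay, with a stated time of 48 h (on this read-out higher numbers stand for weaker inhibition and lower numbers for stronger inhibition), compound 3 gives 126000 nM, the highest number among the three measured compounds. Compound 1 `Cc1ccc(S(=O)(=O)/N=C(/CCNC2=CC(=O)c3ccccc3C2=O)Nc2cccc(C)c2)cc1` gives 18700 nM and compound 2 `COc1ccc(N/C(CCNC2=CC(=O)c3ccccc3C2=O)=N\S(=O)(=O)c2ccc(C)cc2)cc1OC` gives 20500 nM in this assay; those two lie within the scatter of each other (a 1.1-fold higher number from compound 1 to compound 2 (0.04 log units; within the scatter)). Compound 3 stands apart from both: a 6.7-fold higher number from compound 1 to compound 3 (0.83 log units; beyond the scatter) and a 6.1-fold higher number from compound 2 to compound 3 (0.79 log units; beyond the scatter).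

Compound 4 `Cc1ccc(S(=O)(=O)/N=C(/CCNC2=CC(=O)c3ccccc3C2=O)Nc2cc(F)c(F)c(F)c2)cc1` differs from compound 3 in one place: 3,4,5-trifluorophenyl in place of 2,4-dimethoxyphenyl on an amine nitrogen. Among the measured compounds shown here, no measured pair carries this exact change. For the measured compounds named here, the steps that bear on it are the two into compound 3, a 6.7-fold higher number from compound 1 to compound 3 (0.83 log units; beyond the scatter) and a 6.1-fold higher number from compound 2 to compound 3 (0.79 log units; beyond the scatter), which place the 2,4-dimethoxyphenyl at the highest number of the series. Compound 4 carries neither a methoxy group nor the 2,4-dimethoxyphenyl, yet a trifluorophenyl has no measured neighbour in this set. A modest fall in number beyond the scatter is therefore expected, a 4.2-fold lower number from compound 3 to compound 4 (0.62 log units; beyond the scatter), with wide uncertainty. Compound 4 is estimated at 30000 nM in this assay, with a range of 10000 nM to 100000 nM.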

Compound 4, half-maximal inhibitory concentration: 10200 nM
The estimate for compound 4 lay 2.9-fold (0.47 log units) above the measured number, and the stated range covers the measured number.
By their numbers in this assay, from the lowest: compounds 4, 1 and 2 (each within the scatter of the next); then compound 3.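

In this assay the 3,4,5-trifluorophenyl on the amine nitrogen gives a 12-fold lower number from compound 3 to compound 4 (1.09 log units; beyond the scatter), the largest step in the series, so a high number does not follow from every change of aryl group at this position. Among the compounds shown here, compound 4 also falls in with the other two aryl groups, with a 2.0-fold lower number from compound 2 to compound 4 (0.30 log units; within the scatter) and a 1.8-fold lower number from compound 1 to compound 4 (0.26 log units; within the scatter), which leaves 2,4-dimethoxyphenyl in compound 3 as the only group of the four that stands apart, while a ring bearing fluorine alone, one bearing methyl and one bearing 3,4-dimethoxy cannot be told apart here. No measurement bears on why compound 3 differs.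

On these data alone, whether a plain phenyl, a chlorophenyl or a cyclohexyl on this nitrogen would join compounds 1, 2 and 4 remains open. Also open, as far as these compounds go, is whether any group here can reach a number clearly lower than theirs.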